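Cytotoxicity notes: 4-nitrophenyl to 2-fluorophenyl

The source may report more compounds than this note shows. Statements on the series, on what has been measured and on what is new or still open speak of the compounds shown alone.

- Compound 1 `COC(=O)c1c(NCc2ccc(C(C)(C)C)cc2)noc1-c1ccc(Cl)cc1Cl` gives "not determined" (no result reported)
- Compound 2 `COC(=O)c1c(NCCCCNc2ccnc3cc(Cl)ccc23)noc1-c1ccc([N+](=O)[O-])cc1` gives 136000 nM

Among the compounds with values here, in an ADME assay on J774.A1 cells (Mus musculus) for cytotoxicity, read by MTT assay, with a stated time of 48 h (a higher number here means that more compound is tolerated, a lower number that less compound is tolerated), compound 2 gives 136000 nM as the only number so far, and compound 1 has no reported result. Compound 2 therefore has no measured neighbour against which to rank it.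

Compound 3 `COC(=O)c1c(NCCCCNc2ccnc3cc(Cl)ccc23)noc1-c1ccccc1F` carries 2-fluorophenyl in place of 4-nitrophenyl on an aromatic carbon and is still to be measured. What a change at this place does in this assay is not shown by any measured pair. The expectation rests on compound 2 at 136000 nM alone and foresees no shift beyond the scatter in either direction. Expected is a 1.4-fold lower number from compound 2 to compound 3 (0.13 log units; within the scatter) as an estimate, within the scatter. Compound 3 is expected at 100000 nM within an estimated range of 40000 nM to 250000 nM for now.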

Compound 3, half-maximal cytotoxic concentration: 70900 nM
The estimate for compound 3 lay 1.4-fold (0.15 log units) above the measured number, and the stated range covers the measured number.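

In this assay, within the data shown here, 2-fluorophenyl in place of 4-nitrophenyl on the aromatic carbon next to the ring oxygen gives a 1.9-fold lower number from compound 2 to compound 3 (0.28 log units; within the scatter), the first measured pair at this place. The two groups therefore cannot be told apart in this read-out, although 4-nitrophenyl carries hydrogen-bond acceptors and 2-fluorophenyl carries none. No accompanying measurement gives a reason for the size of this step.

Going by these compounds, only these two aryl groups have numbers at this place, so it remains open whether unsubstituted phenyl, 4-methoxyphenyl or a pyridyl group would also stay within the scatter. On these data alone, the methoxycarbonyl group is shared by compound 2 and compound 3, so the effect of a carboxylic acid or an amide there in this assay also remains open.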